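The source may hold more compounds than are shown below. What is called first, only, known or untested is meant among the compounds shown, and "the series" means these compounds.

Two compounds here share one core and differ only in the aryl group on the sulfonyl sulfur. Compound 1 `COc1ccc(OC)c(S(=O)(=O)NC2=NCCN2C(=S)SN2CCn3c2nsc3=S)c1` carries a 2,5-dimethoxyphenyl there. In a functional assay on KYSE-510 cells (Homo sapiens) for antiproliferative activity, read by crystal violet staining, with a stated time of 96 h (on this read-out higher numbers stand for weaker inhibition of growth and lower numbers for stronger inhibition of growth), compound 1 gives >= 20000 nM, which is only a limit and not a number. Compound 2 `O=S(=O)(NC1=NCCN1C(=S)SN1CCn2c1nsc2=S)c1cccc(Cl)c1` carries a 3-chlorophenyl in that position. In this assay compound 2 gives >= 20000 nM, again a limit rather than a number. The step that the two limits leave unreadable from compound 1 to compound 2 therefore has no readable size, since both values sit at the limit of >= 20000 nM in this assay, at which 2 of the 2 values shown sit. Compound 3 `O=S(=O)(NC1=NCCN1C(=S)SN1CCn2c1nsc2=S)c1ccc(Cl)c(Cl)c1Cl` takes the next step: 2,3,4-trichlorophenyl in place of 3-chlorophenyl on a sulfonyl sulfur. For the measured compounds named here, no measured step bears on this change with a readable size, so nothing points to a direction. Compound 3 is therefore expected to give about 25000 nM in this assay, within 10000 nM to 60000 nM, and the expected step that the limit leaves unreadable from compound 2 to compound 3 is none beyond the scatter, most likely reported once more only as a limit.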

Compound 3, concentration for 50% growth inhibition: >= 20000 nM
Compound 3: no number, only a limit; the forecaster's own chance of this, stated with the estimate: 80%; the middle value lies beyond the limit too.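

In this assay compound 3 gives >= 20000 nM, which is a limit and not a number. For the compounds shown here, no step among compound 1, compound 2 and compound 3 can therefore be read: the limit of >= 20000 nM in this assay, at which 3 of the 3 values shown sit. The compounds shown leave open whether swapping the aryl group on the sulfonyl sulfur changes growth inhibition at all.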